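The source may hold more compounds than are shown below. What is called first, only, known or untested is meant among the compounds shown, and "the series" means these compounds.

Compound 2 `COc1ccc(-c2cc3ccccc3nc2/C=C/C(=O)c2ccc(N)cc2)cc1` gives 7400 nM in a functional assay on NCI-H460 cells (Homo sapiens) for antiproliferative activity, read by XTT assay, with a stated time of 72 h; a higher number here means a weaker inhibitor, a lower number a stronger inhibitor; compound 1 `COc1ccc(-c2cc3ccccc3nc2/C=C/C(=O)c2ccc(OC)c(OC)c2)cc1` gives 7540 nM, and the two lie within the scatter of each other, the step of a 1.0-fold lower number from compound 1 to compound 2 (0.01 log units; within the scatter) being flat. Compound 3 `COc1ccc(-c2cc3ccccc3nc2/C=C/C(=O)c2cnc(N)nc2C)cc1` differs from compound 2 by 2-amino-4-methylpyrimidin-5-yl in place of 4-aminophenyl on a carbonyl carbon. Going by the values given here, the one measured step also swaps the group on the carbonyl carbon and shows no movement, but no step yet exchanges a ring of carbon only for a ring with 2 hetero atoms, so the expectation for compound 3 rests on a single flat comparison: a step of no change at the digits printed from compound 2 to compound 3 (within the scatter) of no size beyond the scatter is expected. Compound 3 is estimated at 7400 nM, range 2500 nM to 22000 nM.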

Compound 3, half-maximal inhibitory concentration: > 10000 nM
Compound 3: a limit, no number; the forecaster's own chance of this, stated with the estimate: 5%; at least 1.3-fold (0.13 log units) between middle value and limit.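

In this assay compound 3, with 2-amino-4-methylpyrimidin-5-yl on the carbonyl carbon, gives a limit of the assay and no number: the limit of > 10000 nM in this assay, at which 1 of the 3 values shown sits.

The steps therefore read only as floors, an at least 1.3-fold higher number from compound 2 to compound 3 (0.13 log units; that floor lies within the scatter) and an at least 1.3-fold higher number from compound 1 to compound 3 (0.12 log units; that floor lies within the scatter), so neither establishes a real loss. Going by these compounds alone, this is the first group at this position without a resolved value, whereas the 4-aminophenyl and 3,4-dimethoxyphenyl groups both gave numbers, within the scatter of each other.

Going by these compounds, the ring nitrogens and the methyl enter together, so their separate contributions remain open. Also open, on these data alone, is how a plain pyrimidin-5-yl or a 4-carboxyphenyl would read on this carbonyl carbon.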